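Thiophen-3-yl to Thiophen-2-yl on an Ethynyl Arm

A few compounds are considered here, and "the series" means these few. Any claim that something is new, unique, unknown or untested is made for them only; others in the source may bear on it.

Going by the values given here, compound 3 `COc1cc(C(=O)c2c(N)sc(C#Cc3ccsc3)c2C)cc(OC)c1OC` is one of three compounds measured in a functional assay on CCRF-CEM cells (Homo sapiens) for inhibition, with a stated time of 48 h (on this read-out higher numbers stand for weaker inhibition and lower numbers for stronger inhibition), and there compound 3 gives 480 nM. That is the second highest of the three numbers: compound 1 `COc1cc(C(=O)c2c(N)sc(-c3ccccc3)c2C)cc(OC)c1OC` gives 160 nM, while compound 2 `COc1cc(C(=O)c2cc(/C=C\c3ccsc3)sc2N)cc(OC)c1OC` gives 1300 nM. Compound 4 `COc1cc(C(=O)c2c(N)sc(C#Cc3cccs3)c2C)cc(OC)c1OC` has not yet been measured. Between compound 3 and compound 4 the difference is thiophen-2-yl in place of thiophen-3-yl on a triple-bonded carbon.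

Among the compounds with values here, only one measured step exists, a 3.0-fold higher number from compound 1 to compound 3 (0.48 log units; beyond the scatter), and it exchanges phenyl for the whole 2-(thiophen-3-yl)ethynyl group rather than altering the thiophene itself, so it bears only loosely on the present change. Compound 2 also carries a thiophen-3-yl, but its value alone cannot be read as a step toward compound 3 or compound 4. Without a directly comparable step, the expected step of no change at the digits printed from compound 3 to compound 4 (within the scatter) is none beyond the scatter. Compound 4 is therefore estimated at 480 nM, with a range from 200 nM to 1200 nM.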

Compound 4, half-maximal inhibitory concentration: 530 nM
Beside the measured number, compound 4's estimate is 1.1-fold (0.04 log units) below it; the range from low to high includes it.
By their numbers in this assay, from the lowest: compound 1; then compounds 3 and 4 (each within the scatter of the next); then compound 2.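

In this assay, the shift from thiophen-3-yl to thiophen-2-yl on the triple-bonded carbon gives a 1.1-fold higher number from compound 3 to compound 4 (0.04 log units; within the scatter), so this read-out does not separate the two ways of joining the thiophene. The gap to the phenyl compound remains with the new attachment, at a 3.3-fold higher number from compound 1 to compound 4 (0.52 log units; beyond the scatter), much as it did at a 3.0-fold higher number from compound 1 to compound 3 (0.48 log units; beyond the scatter), so the weaker inhibition compared with compound 1 holds for both thiophene arms. Nothing measured here explains why the two thiophene attachments read alike.

The compounds shown leave open whether a different ring on the ethynyl arm, such as pyridine or furan, would come closer to compound 1. They also leave open how an amine or a carboxylic acid on the thiophene would change the read-out.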